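The compounds below may be only part of what the source reports. "The series", "measured", "known", "first", "only" and "open" are said of these compounds alone.

Of the compounds shown here, three sharing one core have been tested so far: compound 1 `N#Cc1cc(=O)[nH]c(=O)n1[C@@H]1O[C@H](CO)[C@@H](O)[C@H]1O`, compound 2 `[N-]=[N+]=Nc1cc(=O)[nH]c(=O)n1[C@@H]1O[C@H](CO)[C@@H](O)[C@H]1O` and compound 3 `Nc1cc(=O)[nH]c(=O)n1[C@@H]1O[C@H](CO)[C@@H](O)[C@H]1O`. In a functional assay on SKW3 cells (Homo sapiens) for antiproliferative activity, read by WST assay, with a stated time of 3 days (on this read-out lower numbers stand for stronger inhibition and higher numbers for weaker inhibition), compound 2 gives > 50000 nM, which is a limit of the assay and not a number. Compound 1 gives > 50000 nM, also a limit. Compound 3 gives > 50000 nM, again a limit. Compound 2 therefore has no readable rank among its neighbours, and the whole picture so far is the limit of > 50000 nM in this assay, at which 3 of the 3 values shown sit.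

The next compound, compound 4 `CNc1cc(=O)[nH]c(=O)n1[C@@H]1O[C@H](CO)[C@@H](O)[C@H]1O`, carries methylamino in place of azido on an aromatic carbon. The closest measured change is a step that the two limits leave unreadable from compound 2 to compound 3, which also replaces azido with a nitrogen group. The other two, a step that the two limits leave unreadable from compound 1 to compound 2 and a step that the two limits leave unreadable from compound 1 to compound 3, give no size either. With only these unreadable steps to go on, no step beyond the scatter is expected in this assay, in either direction, and another limit is the likeliest report. The expected step is a number no higher from compound 2 to compound 4 (the limit leaves the size open). For compound 4 the estimate is 50000 nM, with an expected range from 25000 nM to 100000 nM.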

Compound 4, half-maximal inhibitory concentration: > 50000 nM
Compound 4 gave a limit, no number; the forecaster's own chance of this, stated with the estimate: 85%; the middle value lies on the limit itself.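

In this assay compound 4 gives > 50000 nM, again a limit and not a number. Its steps from compound 1, compound 2 and compound 3 therefore cannot be read, and the picture stays as it was: the limit of > 50000 nM in this assay, at which 4 of the 4 values shown sit. The compounds shown leave open how these four groups compare in this assay.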